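Propyl Gives Way to 4-Hydroxyphenyl on the Shared Core

A few compounds are considered here, and "the series" means these few. Any claim that something is new, unique, unknown or untested is made for them only; others in the source may bear on it.

Among the compounds with values here, in a physicochemical assay for lipophilicity, measured as octanol-water partition (on this read-out lower numbers stand for lower lipophilicity and higher numbers for higher lipophilicity), compound 1 `CCCC1C(C(=O)OCc2ccccn2)=C(C)NC2=C1C(=O)CCC2` gives 2.6 and stands highest of the two numbers known so far, with compound 2 `COc1ccc(C2C(C(=O)OCc3cccnc3)=C(C)NC3=C2C(=O)CCC3)cc1` at 1.54 lower beyond the scatter. Compound 3 `CC1=C(C(=O)OCc2ccccn2)C(c2ccc(O)cc2)C2=C(CCCC2=O)N1` carries 4-hydroxyphenyl in place of propyl on a saturated ring carbon and remains unmeasured. Within the data shown here, no measured pair isolates this change, so the only guide is compound 2 at 1.54 with a six-membered aromatic ring of carbon only in that place too. A drop beyond the scatter is expected in this assay and the estimated step is a number 1.00 log units lower from compound 1 to compound 3 (beyond the scatter) on that guide. Compound 3 is estimated at 1.6 with an expected range from 1 to 2.3 in this measurement.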

Compound 3, partition coefficient: 1.58
For compound 3 the middle estimate is 0.02 log units above the measured one, and the stated range covers the measured number.
By their numbers in this assay, from the lowest: compounds 2 and 3 (each within the scatter of the next); then compound 1.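

In this assay, within the data shown here, putting 4-hydroxyphenyl in place of propyl on a saturated ring carbon gives the first step that isolates a single place on the shared core: a number 1.02 log units lower from compound 1 to compound 3 (beyond the scatter). This position therefore registers the change strongly, and the read-out falls even though the entering group has more heavy atoms. Nothing at hand gives a reason for the size of this step. The compounds shown leave open where plain phenyl, without the hydroxyl, or a longer chain such as pentyl would fall at this place. They also leave open whether an amine in place of the hydroxyl would give a similar step.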